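The source may report more compounds than this note shows. Statements on the series, on what has been measured and on what is new or still open speak of the compounds shown alone.

The measured compounds in a functional assay on HCT-15 cells (Homo sapiens) for cytotoxicity, read by CCK-8 assay and cell counting, with a stated time of 2 days; on this read-out lower numbers stand for stronger inhibition and higher numbers for weaker inhibition:
compound 1 `Oc1cccc(-c2cc(-c3ccc(Cl)cc3)nc(-c3cccs3)c2)c1` gives 9280 nM;
compound 3 `Oc1ccc(-c2cc(-c3ccccc3)nc(-c3ccccc3Cl)c2)cc1` gives 4990 nM;
compound 2 `Oc1cccc(-c2cc(-c3ccncc3)nc(-c3ccccc3Cl)c2)c1` gives "not determined" (no result reported).

In this assay, for the measured compounds named here, only two numbers exist. Compound 1 and compound 3 lie within the usual scatter of each other, so neither stands apart from the other, and compound 2 adds no number. Compound 4 `Oc1cccc(-c2cc(-c3ccc(Cl)cc3)nc(-c3ccsc3)c2)c1` keeps the core of compound 1 together with its 3-hydroxyphenyl and 4-chlorophenyl groups and differs only by thiophen-3-yl in place of thiophen-2-yl on an aromatic carbon. Going by the values given here, no measured pair shows a step of this kind, so the expectation rests on compound 1 alone. The expected step is a 1.0-fold lower number from compound 1 to compound 4 (0.01 log units; within the scatter), within the scatter and in no firm direction. Compound 4 is therefore estimated to give 9000 nM, in the range 3000 nM to 27000 nM.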

Compound 4, half-maximal inhibitory concentration: 8850 nM
Compound 4: the middle estimate sits 1.0-fold (0.01 log units) above what was measured, and the stated range covers the measured number.
By their numbers in this assay, from the lowest: compounds 3, 4 and 1 (each within the scatter of the next).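

In this assay, for the compounds shown here, thiophen-3-yl in place of thiophen-2-yl, on the aromatic carbon next to the ring nitrogen, gives a 1.0-fold lower number from compound 1 to compound 4 (0.02 log units; within the scatter), the first comparison here of compounds that differ in one place. At this position, the read-out does not separate the two thiophene attachments. Nothing available explains why they read alike. The compounds shown leave open whether a morpholine or a carboxylic acid at this position would give a step beyond the scatter. They also leave open how this position behaves with other groups on the shared core.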